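Ethoxy in place of methyl: working notes on the series

The source may report more compounds than this note shows. Statements on the series, on what has been measured and on what is new or still open speak of the compounds shown alone.

Values in a functional assay on K562 cells (Homo sapiens) for inhibition; on this read-out higher numbers stand for weaker inhibition and lower numbers for stronger inhibition
Compound 1 (`CCOc1ccc(Br)cc1-c1cc(Nc2ccc(C(C)=O)cc2)nc(N)n1`) gives 50 nM
Compound 2 (`Cc1ccc(Br)cc1-c1cc(Nc2ccc(Cl)cc2)nc(N)n1`) gives 70 nM

Compound 2 stands at 70 nM and lies within the scatter of compound 1 at 50 nM so the two values set no order. Compound 3 (`CCOc1ccc(Br)cc1-c1cc(Nc2ccc(Cl)cc2)nc(N)n1`) has not yet been measured. Relative to compound 2 it carries ethoxy in place of methyl on an aromatic carbon and no measured pair isolates this change. Compound 1 also carries ethoxy and stands at 50 nM in this assay so no step beyond the scatter is expected. The estimated change is a 1.3-fold lower number from compound 2 to compound 3 (0.10 log units; within the scatter) and is expected to stay within the scatter. For compound 3 the expected value is 55 nM with an estimated range from 20 nM to 150 nM as its span.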

Compound 3, half-maximal inhibitory concentration: 50 nM
Beside the measured number, compound 3's estimate is 1.1-fold (0.04 log units) above it, within the range that was stated.
By their numbers in this assay, from the lowest: compounds 1, 3 and 2 (each within the scatter of the next).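

In this assay, ethoxy in place of methyl on an aromatic carbon, ortho to a large group and para to a bromo group, now has a matched pair: a 1.4-fold lower number from compound 2 to compound 3 (0.15 log units; within the scatter). At this position, the step from methyl to ethoxy therefore sets no order between the two groups, and the second matched pair, chloro in place of acetyl on an aromatic carbon, likewise sets none, with no change at the digits printed from compound 1 to compound 3 (within the scatter). Nothing available on these compounds gives a reason for either result.

Going by these compounds, whether an amine or a longer chain such as butoxy at the ethoxy position would move the number beyond the scatter remains open. All the compounds shown also carry the bromo group, so whether the ethoxy step holds with a nitrile there is equally open.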